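Dropping the methoxy group of compound 2

The source may hold more compounds than are shown below. What is called first, only, known or untested is meant among the compounds shown, and "the series" means these compounds.

For the measured compounds named here, compound 2 `COc1ccc2nc(C(=O)Nc3ccc(-c4ccccc4)cc3)c(C)c(O)c2c1` is one of two compounds measured here. In a functional assay on Hep 3B2 cells (Homo sapiens) for antiproliferative activity, read by MTT assay, with a stated time of 24 h, tested at 0.02 ug/mL (a higher number here means a stronger effect of the compound at the concentration tested, a lower number a weaker effect), compound 2 gives 0.96%, the higher of the two numbers. Compound 1 `CCOc1ccc2nc(C(=O)Nc3c(F)cc(-c4cccc(F)c4)cc3F)c(C)c(O)c2c1` gives -0.32% in this assay, a number within the scatter of that of compound 2, so the two cannot be ranked against each other. Both numbers show essentially no inhibition at the concentration tested.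

Compound 3 `Cc1c(C(=O)Nc2ccc(-c3ccccc3)cc2)nc2ccccc2c1O` has not yet been measured in this assay. It differs from compound 2 in one place: hydrogen in place of methoxy on an aromatic carbon. Going by the values given here, no step between measured compounds is available to gauge what such a change does here, and neither measured value departs from zero beyond the scatter.

The expectation for this step therefore rests on compound 2 alone. The expected step of a number 0 percentage points higher from compound 2 to compound 3 (within the scatter) is none beyond the scatter. This expectation is grounded in compound 2, which gives 0.96% in this assay, a reading that leaves little room for a drop and gives no reason to anticipate a rise. For compound 3 the estimated value in this assay is 1%, with a range from -8% to 10%.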

Compound 3, a percentage reported as inhibition, at one concentration (the size of the read-out at that concentration, not a potency): 1.05%
For compound 3 the middle estimate is 0.1 percentage points below the measured one; the measured number falls inside the stated range.
By their numbers in this assay, from the lowest: compounds 1, 2 and 3 (each within the scatter of the next).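

For the compounds shown here, replacing methoxy with hydrogen on this aromatic carbon gives the first step between measured compounds that differ in one place: in this assay it is a number 0.1 percentage points higher from compound 2 to compound 3 (within the scatter). With the methoxy group gone, compound 3 still shows essentially no inhibition at the single concentration tested, so the group is not needed to keep the reading where it stands in compound 2. Since that reading already sits near zero, however, the step cannot show whether the methoxy group would matter in a compound with a clear effect, and no measured evidence bears on the outcome.

From the compounds shown here alone, it remains open whether an amine or a chlorine atom on this aromatic carbon would move the reading in this assay beyond the scatter. Going by these compounds, it is also open whether compound 2 and compound 3 would differ at a higher concentration, where a real effect could be compared.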